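Fluoro for Methoxy: Expected Cytotoxicity of Compound 4

This account rests on a few compounds, and the source may have more. Where it says the series, first, only, none or still open, it means among the compounds named here.

Three compounds have so far been examined in an ADME assay on PBMC cells (Homo sapiens) for cytotoxicity, read by MTT assay, with a stated time of 72 h, in the absence of a further agent; a higher number here means a weaker inhibitor, a lower number a stronger inhibitor. Compound 1 `COc1ccc(Nc2ccc3ccccc3n2)cc1` gives 91000 nM in this assay, the lowest of the two numbers recorded. Compound 2 `Cc1ccc(-c2ccnc(Nc3ccc(F)cc3)c2)cc1` gives 127000 nM in this assay; the gap between compounds 1 and 2 lies within the scatter, so no order between the two can be read. Compound 3 `CCc1ccc(Nc2cc(-c3cccc(C(F)(F)F)c3)ccn2)cc1` gives "not determined" (no result reported) in this assay, so no result is reported for it.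

Compound 4 `Fc1ccc(Nc2ccc3ccccc3n2)cc1` has not yet been measured. It differs from compound 1 in one place: fluoro in place of methoxy on an aromatic carbon. Within the data shown here, no step between measured compounds speaks to this change, so the expectation rests on compound 1 alone. The step of a 1.1-fold higher number from compound 1 to compound 4 (0.04 log units; within the scatter) is expected to stay within the scatter, in no particular direction, since compound 1 gives 91000 nM and nothing measured points elsewhere. Compound 4 is therefore estimated to give 100000 nM in this assay, within a range from 40000 nM to 250000 nM.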

Compound 4, half-maximal inhibitory concentration: 90000 nM
Beside the measured number, compound 4's estimate is 1.1-fold (0.05 log units) above it; low and high end bracket the measured number.
By their numbers in this assay, from the lowest: compounds 4, 1 and 2 (each within the scatter of the next).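

Fluoro in place of methoxy, on an aromatic carbon para to a large group, gives a 1.0-fold lower number from compound 1 to compound 4 (0.00 log units; within the scatter) in this assay. Among these compounds, this is the first direct reading of a change at this position, and it shows that replacing the methoxy, with its oxygen and its hydrogen-bond acceptor, by a single fluorine atom does not move the number beyond the scatter on the core of compound 1. No measured evidence bears on why the number holds at this position.

With only fluoro and methoxy shown here, it remains open whether an amine, a carboxylic acid or a longer chain at the same position would also leave the number within the scatter. As far as these compounds go, it also remains open whether fluoro in place of methoxy would read the same on a different core.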